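The compounds below may be only part of what the source reports. "The series", "measured", "known", "first", "only" and "open" are said of these compounds alone.

Three compounds sharing one core have numbers in a functional assay on G-361 cells (Homo sapiens) for cytotoxicity, read by fluorescence, with a stated time of 72 h; on this read-out lower numbers stand for stronger inhibition and higher numbers for weaker inhibition: compound 1 `CC(C)c1n[nH]c2c(NCc3ccc(-c4ccccn4)cc3)nc(NCC(C)(C)O)nc12` gives 48 nM, compound 2 `CC(C)c1n[nH]c2c(NCc3ccc(-c4ccccn4)cc3)nc(N3CCCCC3CCO)nc12` gives 204 nM, and compound 3 `CC(C)c1n[nH]c2c(NCc3ccc(-c4ccccn4)cc3)nc(NCCN)nc12` gives 230 nM. Compound 3 thus shares the high end of this small set, since the two higher numbers cannot be told apart: a 1.1-fold higher number from compound 2 to compound 3 (0.05 log units; within the scatter). The lowest number stands apart from both, with a 4.3-fold higher number from compound 1 to compound 2 (0.63 log units; beyond the scatter) and a 4.8-fold higher number from compound 1 to compound 3 (0.68 log units; beyond the scatter).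

Compound 4 `CC(C)c1n[nH]c2c(NCc3ccc(-c4ccccn4)cc3)nc(NCC(N)CO)nc12` differs from compound 3 at one place: hydroxymethyl in place of hydrogen on a saturated chain carbon bound to an amine nitrogen and a saturated chain carbon. The aminomethyl end of the chain stays, and a hydroxymethyl is added on that same chain carbon. The closest evidence is the exchange of 1-hydroxy-1-methylethyl for aminomethyl, a 4.8-fold higher number from compound 1 to compound 3 (0.68 log units; beyond the scatter), which suggests that a hydroxy-bearing chain can go with a lower number. Compound 2 goes against this, as it also carries a hydroxy-bearing group yet gives 204 nM. Only a small move towards lower numbers is therefore expected, close to the scatter: a 1.8-fold lower number from compound 3 to compound 4 (0.25 log units; within the scatter). For compound 4 the estimated value is 130 nM, with an expected range of 45 nM to 350 nM.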

Compound 4, half-maximal inhibitory concentration: 1020 nM
Compound 4: the middle estimate sits 7.8-fold (0.89 log units) below what was measured; the measured number lies above the stated range.
By their numbers in this assay, from the lowest: compound 1; then compounds 2 and 3 (each within the scatter of the next); then compound 4.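

Adding hydroxymethyl to the saturated chain carbon of compound 3 raises the number in this assay rather than lowering it (a 4.4-fold higher number from compound 3 to compound 4 (0.65 log units; beyond the scatter)), so this chain carbon responds to the change by more than the scatter. Together with compound 2, compound 4 goes against the idea that a hydroxy-bearing group goes with a lower number, and it sits clearly above both compound 2 (a 5.0-fold higher number from compound 2 to compound 4 (0.70 log units; beyond the scatter)) and compound 1 (a 21-fold higher number from compound 1 to compound 4 (1.33 log units; beyond the scatter)), the last being the largest step in this set. No measurement offered here accounts for the rise.

As far as these compounds go, whether the rise follows from the hydroxy group or from any added group on that carbon stays open, and a methyl there would help to separate the two. Also open, from the compounds shown here alone, is whether the amine at the chain end matters to the result, which a 2,3-dihydroxypropyl chain could test.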